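The source may report more compounds than this note shows. Statements on the series, on what has been measured and on what is new or still open speak of the compounds shown alone.

Measured compounds:
- compound 1 `CCOC(=O)c1sc2ccc(NCc3c[nH]cn3)cc2c1NC(=O)c1ccc(C(F)(F)F)cc1`: 16800 nM
- compound 2 `CCOC(=O)c1sc2ccc(NCc3nc[nH]c3C)cc2c1NC(=O)c1ccccc1`: 23300 nM
- compound 3 `CCOC(=O)c1sc2ccc(N)cc2c1NC(=O)c1ccccc1`: > 50000 nM

All three share one core and were tested in a functional assay on HeLa cells (Homo sapiens) for antiproliferative activity, read by MTT assay, with a stated time of 48 h; a lower number here means a stronger inhibitor of growth, a higher number a weaker inhibitor of growth. For compound 3 the result is only a limit of the assay, > 50000 nM, not a number; it therefore stands at the weak end of what is shown, at the limit of > 50000 nM in this assay, at which 1 of the 3 values shown sits. Among the measured compounds shown here, the one measured step, an at least 2.1-fold higher number from compound 2 to compound 3 (0.33 log units; beyond the scatter), moves the value from a number onto that limit.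

Compound 4 `CCOC(=O)c1sc2ccc(N)cc2c1NC(=O)c1ccc(C(F)(F)F)cc1` differs from compound 3 in a single place: trifluoromethyl in place of hydrogen on an aromatic carbon. For the measured compounds named here, no measured step follows this change on its own. Compounds 1 and 2 differ in two places at once, and their values in this assay sit close to each other, which gives no sign that the trifluoromethyl group alone shifts the number much. For compound 4 the expectation is therefore a step that the limit leaves unreadable from compound 3 to compound 4, that is, little change beyond the scatter and a fair chance of another limit. The estimate for compound 4 in this assay is 60000 nM, within 25000 nM to 150000 nM.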

Compound 4, concentration for 50% growth inhibition: 6680 nM
Beside the measured number, compound 4's estimate is 9.0-fold (0.95 log units) above it, and the stated range ends above it.
By their numbers in this assay, from the lowest: compound 4; then compounds 1 and 2 (each within the scatter of the next). At a limit, above all of these: compound 3.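

Trifluoromethyl in place of hydrogen, on an aromatic carbon para to a large group, clearly matters in this assay, giving an at least 7.4-fold lower number from compound 3 to compound 4 (0.87 log units; beyond the scatter). The starting point of that step is a limit and not a number: the limit of > 50000 nM in this assay, at which 1 of the 4 values shown sits. With trifluoromethyl present, the side group on the nitrogen is no longer needed for activity, since hydrogen in place of (1H-imidazol-4-yl)methyl gives a 2.5-fold lower number from compound 1 to compound 4 (0.40 log units; beyond the scatter), the opposite direction to an at least 2.1-fold higher number from compound 2 to compound 3 (0.33 log units; beyond the scatter), where the group lost is (5-methyl-1H-imidazol-4-yl)methyl.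

The compounds shown leave open whether this gain is particular to trifluoromethyl or would also come with a chlorine, a methyl or a nitrile on the same aromatic carbon. They also leave open how a longer chain or an acetyl group on the free amine of compound 4 would change its number.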